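Acyl ester variation in a topoisomerase 1 inhibitor series

The compounds below may be only part of what the source reports. "The series", "measured", "known", "first", "only" and "open" are said of these compounds alone.

Measured compounds:
compound 1, `CC(C)=CC[C@@H](OC(=O)CCl)C1=CC(=O)c2c(O)ccc(O)c2C1=O`: 137000 nM
compound 2, `CC(C)=CC[C@@H](OC(=O)C(Cl)(Cl)Cl)C1=CC(=O)c2c(O)ccc(O)c2C1=O`: 115000 nM
compound 3, `CC(C)=CC[C@@H](OC(=O)C(C)C)C1=CC(=O)c2c(O)ccc(O)c2C1=O`: 84000 nM

The three compounds share one core and differ only in the acyl group of the ester. In an assay on HeLa cells for inhibition of DNA topoisomerase 1 (Homo sapiens) (on this read-out lower numbers stand for stronger inhibition and higher numbers for weaker inhibition), compound 1 gives 137000 nM, compound 2 gives 115000 nM and compound 3 gives 84000 nM. All steps between them are small: a 1.2-fold lower number from compound 1 to compound 2 (0.08 log units; within the scatter), a 1.6-fold lower number from compound 1 to compound 3 (0.21 log units; within the scatter) and a 1.4-fold lower number from compound 2 to compound 3 (0.14 log units; within the scatter). Compound 3 carries the lowest of the three numbers, but its gaps to compound 2 and to compound 1 both stay within the scatter, so the three acyl groups cannot be ranked on this read-out.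

Compound 4, `C/C=C/C=C/C(=O)O[C@H](CC=C(C)C)C1=CC(=O)c2c(O)ccc(O)c2C1=O`, has not been measured in this assay. Against compound 3 the change is penta-1,3-dien-1-yl in place of isopropyl on a carbonyl carbon; the entering chain carries two double bonds outside aromatic rings, and the carbonyl carbon's other neighbour is an oxygen next to a carbonyl group. Among the measured compounds shown here, none of the measured steps introduces such a chain; the three exchanges seen here, all at the same carbonyl carbon, stayed within the scatter. The expectation for compound 4 is therefore no step beyond the scatter, with the estimated step of a 1.1-fold lower number from compound 3 to compound 4 (0.02 log units; within the scatter). Compound 4 is estimated at 80000 nM, within 35000 nM to 190000 nM.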

Compound 4, half-maximal inhibitory concentration: 130000 nM
Beside the measured number, compound 4's estimate is 1.6-fold (0.21 log units) below it, and the stated range covers the measured number.
By their numbers in this assay, from the lowest: compounds 3, 2, 4 and 1 (each within the scatter of the next).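

In this assay the series now includes penta-1,3-dien-1-yl, an entering chain of 5 carbon atoms with 2 double bonds outside aromatic rings, on the same carbonyl carbon. The steps of a 1.5-fold higher number from compound 3 to compound 4 (0.19 log units; within the scatter), a 1.1-fold higher number from compound 2 to compound 4 (0.05 log units; within the scatter) and a 1.1-fold lower number from compound 1 to compound 4 (0.02 log units; within the scatter) all lie within the scatter, so this chain cannot be ranked against isopropyl, trichloromethyl or chloromethyl at this position. Even with a longer chain carrying double bonds, the exchanges seen at this carbonyl carbon show no step beyond the scatter, and no evidence on hand explains the closeness of the four numbers.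

The compounds shown leave open whether an acyl group carrying a phenyl ring, an amine or a carboxylic acid would give a step beyond the scatter at this carbonyl carbon. They also leave open whether the double bonds or the chain length matter for penta-1,3-dien-1-yl, a question that a saturated pentyl chain at the same place would help to separate.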